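Swapping the Ring Sulfur for Carbon in Compound 2

The compounds below may be only part of what the source reports. "The series", "measured", "known", "first", "only" and "open" are said of these compounds alone.

Compound 1 `N/C(=N\NC(=S)N1CCOCC1)c1ccccn1` and compound 2 `N/C(=N\NC(=S)N1CCSCC1)c1ccccn1` share the same core and differ only in the six-membered ring attached to the thiocarbonyl carbon. In a functional assay on HeLa cells (Homo sapiens) for cytotoxicity, read by MTT assay, with a stated time of 72 h (on this read-out lower numbers stand for stronger inhibition and higher numbers for weaker inhibition), compound 1 gives 7300 nM, and compound 2 gives 7800 nM. Among the compounds with values here, the step of a 1.1-fold higher number from compound 1 to compound 2 (0.03 log units; within the scatter) shows that these two numbers cannot be told apart; compound 2 therefore stands together with compound 1, with no measured compound that is clearly separated from it.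

Compound 3 `N/C(=N\NC(=S)N1CCCCC1)c1ccccn1` is the next variation on the same core. The change from compound 2 is piperidin-1-yl in place of thiomorpholin-4-yl on a thiocarbonyl carbon. Within the data shown here, the only measured step that bears on this change is a 1.1-fold higher number from compound 1 to compound 2 (0.03 log units; within the scatter), where one hetero atom in that ring was exchanged for another and nothing happened beyond the scatter. On that basis, removing the hetero atom altogether is expected to leave this assay essentially unchanged, in no particular direction. The expected step of a 1.0-fold lower number from compound 2 to compound 3 (0.02 log units; within the scatter) is accordingly small. Compound 3 is thus estimated at 7500 nM, with a range from 3000 nM to 18000 nM.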

Compound 3, half-maximal inhibitory concentration: 3800 nM
Compound 3: the middle estimate sits 2.0-fold (0.30 log units) above what was measured; the measured number falls inside the stated range.
By their numbers in this assay, from the lowest: compounds 3, 1 and 2 (each within the scatter of the next, the first and the last beyond it).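

In this assay, the ring on the thiocarbonyl carbon now gives its first step beyond the scatter, though a modest one: piperidin-1-yl in place of thiomorpholin-4-yl produces a change (a 2.1-fold lower number from compound 2 to compound 3 (0.31 log units; beyond the scatter)), so this position is not wholly indifferent to the ring it carries. The picture is only partial, since piperidin-1-yl in place of morpholin-4-yl stays within the scatter (a 1.9-fold lower number from compound 1 to compound 3 (0.28 log units; within the scatter)), and compound 1 therefore goes against any rule that a ring without a second hetero atom is clearly better than a ring with one. Nothing available explains why the sulfur-containing ring and the carbon-only ring separate in this way.

On these data alone, all three rings have six members, so it remains open how a smaller ring such as pyrrolidin-1-yl, or an open-chain group such as dimethylamino, would behave on this carbon. A piperazin-1-yl ring, with nitrogen as the other hetero atom, would show whether the small separation seen here extends to a further ring of the same size.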